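A few compounds are considered here, and "the series" means these few. Any claim that something is new, unique, unknown or untested is made for them only; others in the source may bear on it.

The series concerns three measured hydroxamic acids built on a shared core and one further compound that has not yet been measured. Compound 1 `COc1cc2c(Oc3ccc(NC(=O)c4nn(-c5ccccc5C)cc(C)c4=O)cc3)ccnc2cc1OCCCC(=O)NO` gives 1600 nM in a functional assay on MCF7 cells (Homo sapiens) for inhibition, read by MTT assay, with a stated time of 72 h; a higher number here means a weaker inhibitor, a lower number a stronger inhibitor. Compound 3 `COc1cc2c(Oc3ccc(NC(=O)c4nn(-c5ccccc5C)cc(C)c4=O)cc3)ccnc2cc1OCCCCCC(=O)NO` gives 1830 nM in this assay. Compound 2 `COc1cc2c(Oc3ccc(NC(=O)c4nn(-c5ccccc5F)cc(C)c4=O)cc3F)ccnc2cc1OCCCCCC(=O)NO` gives 2320 nM in this assay, the highest of the three numbers, though its distance from compound 3 and from compound 1 stays within the scatter. The cores of compound 2 and compound 3 differ, but that difference is not broken down here.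

Compound 3 and compound 1 differ in one place: hydroxycarbamoyl in place of 2-(hydroxycarbamoyl)ethyl on a saturated chain carbon, three bonds along the chain from an oxygen on an aromatic ring. The step of a 1.1-fold lower number from compound 3 to compound 1 (0.06 log units; within the scatter) is within the scatter, so shortening the chain in this way left the read-out essentially unchanged on that core.

Compound 4 `COc1cc2c(Oc3ccc(NC(=O)c4nn(-c5ccccc5F)cc(C)c4=O)cc3F)ccnc2cc1OCCCC(=O)NO` is the compound yet to be measured. It differs from compound 2 by hydroxycarbamoyl in place of 2-(hydroxycarbamoyl)ethyl on a saturated chain carbon, three bonds along the chain from an oxygen on an aromatic ring, the same change that carries compound 3 to compound 1, at the same place on the chain. Because the earlier step of a 1.1-fold lower number from compound 3 to compound 1 (0.06 log units; within the scatter) was flat, the corresponding step from compound 2 to compound 4 is expected to be similarly flat, a 1.1-fold lower number from compound 2 to compound 4 (0.04 log units; within the scatter), resting on the value of compound 2 2320 nM as the starting point. Compound 4 is therefore estimated to give about 2100 nM in this assay, with a likely span from 1000 nM to 4500 nM.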

Compound 4, half-maximal inhibitory concentration: 2100 nM
Estimate against measurement, compound 4: no gap at the digits printed; measured number inside the range.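

In this assay, the new step is a 1.1-fold lower number from compound 2 to compound 4 (0.04 log units; within the scatter), so exchanging 2-(hydroxycarbamoyl)ethyl for hydroxycarbamoyl at this place on the chain leaves the read-out flat on a second core as well. Set side by side, the two steps do not differ, and the change carries from one core to the other without any visible shift: the same change on two cores in this assay, a 1.1-fold lower number (0.06 log units; within the scatter) from compound 3 to compound 1 and a 1.1-fold lower number (0.04 log units; within the scatter) from compound 2 to compound 4, 1.0-fold (0.02 log units) apart, within the scatter of two such steps This shows agreement for these two cores and this one cell read-out only; it does not show that the step would stay flat on any other core, and a change with no visible effect on either core says little about how the core would act on a change of larger size.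

The compounds shown leave open whether the read-out stays flat with a chain outside the 3-(hydroxycarbamoyl)propyl to 5-(hydroxycarbamoyl)pentyl pair on each core, such as (hydroxycarbamoyl)methyl or a longer chain, and whether a carboxylic acid or an amine at the chain end would behave like the hydroxycarbamoyl group. They also leave open what each single difference between the two cores contributes, as those differences are not separated here.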